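A Methoxy Step Repeated on a Second Core

The compounds below may be only part of what the source reports. "The series", "measured", "known", "first", "only" and "open" are said of these compounds alone.

Three compounds were tested in a functional assay on SNB-19 cells (Homo sapiens) for cytotoxicity, read by sulforhodamine B assay, with a stated time of 48 h, tested at 0.01 uM; on this read-out lower numbers stand for a stronger effect and higher numbers for a weaker effect at the one concentration tested. Compound 3 `COc1ccc(-c2cc(/C=C/C(=O)c3ccc(N)cc3)[nH]n2)cc1OC` gives 96%. Compound 1 `COc1cc(-c2cc(/C=C/C(=O)c3ccc(N)cc3)[nH]n2)cc(OC)c1OC` gives 96%; the change between them is methoxy in place of hydrogen on an aromatic carbon, and the step was no change at the digits printed from compound 3 to compound 1 (within the scatter). Compound 2 `COc1ccc(C(=O)/C=C/c2cc(-c3cc(OC)c(OC)c(OC)c3)n[nH]2)cc1OC` gives 91%, and the step was a number 5 percentage points lower from compound 1 to compound 2 (within the scatter). The difference between the cores of compound 2 and compound 3 is not broken down here. Compound 4 `COc1cc(C(=O)/C=C/c2cc(-c3cc(OC)c(OC)c(OC)c3)n[nH]2)cc(OC)c1OC` has not been measured yet. It differs from compound 2 by methoxy in place of hydrogen on an aromatic carbon, the same change as that made from compound 3 to compound 1, with the same surroundings. Because the earlier step was no change at the digits printed from compound 3 to compound 1 (within the scatter), a similarly small step from compound 2 to compound 4 in this assay is expected, namely a number 2 percentage points lower from compound 2 to compound 4 (within the scatter). Compound 4 is therefore estimated at 89%, most likely between 76% and 100%.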

Compound 4, a percentage reported as activity, at one concentration (the size of the read-out at that concentration, not a potency): 92%
Estimate against measurement, compound 4: 3 percentage points below, within the range that was stated.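

In this assay, methoxy in place of hydrogen on the second core gave a number 1 percentage points higher from compound 2 to compound 4 (within the scatter). Set beside the earlier step, the change carried over between the two cores with no difference that can be told apart from the scatter: the same change on two cores in this assay, no change at the digits printed (within the scatter) from compound 3 to compound 1 and a number 1 percentage points higher (within the scatter) from compound 2 to compound 4, 1 percentage points apart, within the scatter of two such steps. Going by these compounds alone, this shows only that both steps stay within the scatter at the one concentration tested; it does not show how the change would behave on a further core or at any other concentration.

The compounds shown leave open what a different group in this place on the aromatic ring would give, such as ethoxy, a chlorine atom or a carboxylic acid. They also leave open whether either core would show a step beyond the scatter with such a group.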